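Amine-tail change from compound 3 to compound 4

The source may hold more compounds than are shown below. What is called first, only, known or untested is meant among the compounds shown, and "the series" means these compounds.

Measured so far, all in a functional assay on the whole organism with Mus musculus as the target, in the maximal electroshock model, at a dose of 50 mg/kg by the oral route; a higher number here means more inhibition at the dose given (going by the name of the read-out), a lower number less inhibition:
- compound 1 `CN(C)CCCCOc1ccccc1/C=C/c1cccc(Cl)c1`, which in this assay gives 14.3%
- compound 2 `CN(C)CCCCOc1ccccc1/C=C/c1ccc(Cl)cc1`, which in this assay gives 0%
- compound 3 `C(=C/c1ccccc1OCCCCN1CCNCC1)\c1ccccc1`, which in this assay gives 0%

Compound 3 sits level with compound 2 at the digits read, the two together the lowest of the three numbers. Its nearest neighbour is compound 2, with no change at the digits read; the furthest is compound 1, whose value lies higher, beyond the scatter.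

Within the data shown here, the only measured step, a number 14.3 percentage points lower from compound 1 to compound 2 (beyond the scatter), concerns the chlorine position on the far aryl ring and says nothing about the amine tail. Compound 4 `O=C(O)C1CCCN(CCCCOc2ccccc2/C=C/c2ccccc2)C1` is compound 3 changed at that tail: 3-carboxypiperidin-1-yl in place of piperazin-1-yl on a saturated chain carbon, four bonds along the chain from an oxygen on an aromatic ring. Among the measured compounds shown here, no measured pair bears on this exchange, so there is no ground for a step of any size beyond the scatter; the expectation rests only on compound 3 standing at 0%.

For compound 4 an inhibition of 3% is expected, within 0% to 20%, which means an expected step of a number 3 percentage points higher from compound 3 to compound 4 (within the scatter), within the scatter.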

Compound 4, a percentage reported as inhibition, in the whole organism at one dose (the size of the read-out at that dose, not a potency): 12.5%
Compound 4: the middle estimate sits 9.5 percentage points below what was measured, within the range that was stated.
By their numbers in this assay, from the lowest: compounds 2 and 3 (each within the scatter of the next); then compounds 4 and 1 (each within the scatter of the next).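

At the amine tail, on a saturated chain carbon, four bonds along the chain from an oxygen on an aromatic ring, the exchange of piperazin-1-yl for 3-carboxypiperidin-1-yl gives, in this assay, a number 12.5 percentage points higher from compound 3 to compound 4 (beyond the scatter). Among these compounds, this is the first sign that the read-out responds to the group at this position, since the only earlier step concerned the chlorine position on the far aryl ring. The exchange changes several things at once: the entering group has more heavy atoms, one ring nitrogen fewer and a double bond outside aromatic rings, while its counted hydrogen-bond donors and acceptors match those of the group it replaces, and nothing available bears on why the number moves.

The compounds shown leave open whether the step belongs to the carboxylic acid or to the piperidine ring itself, a question that a plain piperidin-1-yl tail or a methyl ester in place of the acid would separate. Also open, going by these compounds, is whether the same tail exchange gives a similar step when the far aryl ring carries a chlorine, and how the single-dose read-out would behave at other doses.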